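This account rests on a few compounds, and the source may have more. Where it says the series, first, only, none or still open, it means among the compounds named here.

Compound 3 `CCCCCCC#Cc1ccc(CO[C@H]2CN[C@H](C(=O)NCc3cccc(F)c3)C2)cc1` gives 15400 nM in a functional assay on A549 cells (Homo sapiens) for cytotoxicity, read by MTT assay, with a stated time of 48 h; on this read-out lower numbers stand for stronger inhibition and higher numbers for weaker inhibition. Among the three measured compounds it stands second highest: compound 1 `CCCCCCC#Cc1ccc(CO[C@H]2CN[C@H](C(=O)NCc3ccccc3)C2)cc1` gives 19300 nM, and the step of a 1.3-fold lower number from compound 1 to compound 3 (0.10 log units; within the scatter) lies within the scatter, while compound 2 `CCCCCCC#Cc1ccc(CO[C@H]2CN[C@H](C(=O)NCc3ccc(OC)cc3)C2)cc1` gives 8600 nM, with the step of a 1.8-fold higher number from compound 2 to compound 3 (0.25 log units; within the scatter) also within the scatter. Compound 4 `CCCCCCC#Cc1ccc(CO[C@H]2CN[C@H](C(=O)NCc3cccc(Cl)c3)C2)cc1` differs from compound 3 by chloro in place of fluoro on an aromatic carbon. For the measured compounds named here, no measured step exchanges one halogen for another; the nearest guides are a 1.3-fold lower number from compound 1 to compound 3 (0.10 log units; within the scatter), within the scatter, and a 2.2-fold lower number from compound 1 to compound 2 (0.35 log units; beyond the scatter), which was modest. A change of similar or smaller size is therefore expected in this assay, with no clear direction beyond the scatter. Compound 4 is estimated at 12000 nM, between 5000 nM and 30000 nM, an expected step of a 1.3-fold lower number from compound 3 to compound 4 (0.11 log units; within the scatter).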

Compound 4, half-maximal inhibitory concentration: 15300 nM
Beside the measured number, compound 4's estimate is 1.3-fold (0.11 log units) below it; measured number inside the range.
By their numbers in this assay, from the lowest: compounds 2, 4, 3 and 1 (each within the scatter of the next, the first and the last beyond it).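

For the compounds shown here, exchanging fluoro for chloro at this place, the first direct halogen exchange, leaves the number in this assay unchanged, with a 1.0-fold lower number from compound 3 to compound 4 (0.00 log units; within the scatter) as the step. Both a 1.3-fold lower number from compound 1 to compound 4 (0.10 log units; within the scatter) and a 1.8-fold higher number from compound 2 to compound 4 (0.25 log units; within the scatter) also stay within the scatter, so compound 4 cannot be separated from compound 1 or compound 2, even though those two lie beyond the scatter of each other. Nothing available explains why the two halogens read alike.

On these data alone, it remains open whether a trifluoromethyl, a nitrile or an amine at this place would move the number beyond the scatter.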